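Replacing Acetyl with Methoxybenzyl on a Core at the Limit

The source may report more compounds than this note shows. Statements on the series, on what has been measured and on what is new or still open speak of the compounds shown alone.

Compound 3 `CC(=O)c1ccc2c(c1)/C(=C\c1cccc(OCc3cn(Cc4ccccc4)nn3)c1)C(=O)N2` is one of three close relatives that have been tested in a functional assay on PC-3 cells (Homo sapiens) for inhibition, read by MTT assay, with a stated time of 48 h; a lower number here means a stronger inhibitor, a higher number a weaker inhibitor. In this assay compound 3 gives only a limit, > 50000 nM, and not a measured number. Compound 1 `O=C1Nc2ccc(F)cc2/C1=C\c1cccc(OCc2cn(Cc3ccccc3)nn2)c1` likewise reaches only a limit of > 50000 nM in this assay. Compound 2 `CC(=O)c1ccc2c(c1)/C(=C/c1cccc(OCc3cn(Cc4ccccc4)nn3)c1)C(=O)N2` also stops at a limit of > 50000 nM in this assay. The change of acetyl in place of fluoro gives a step that the two limits leave unreadable from compound 1 to compound 3, and the change from a Z-drawn to an E-drawn double bond gives a step that the two limits leave unreadable from compound 2 to compound 3; neither step can be sized because of the limit of > 50000 nM in this assay, at which 3 of the 3 values shown sit.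

Compound 4 `COc1ccc(Cc2ccc3c(c2)/C(=C\c2cccc(OCc4cn(Cc5ccccc5)nn4)c2)C(=O)N3)cc1` differs from compound 3 by 4-methoxybenzyl in place of acetyl on an aromatic carbon. For the measured compounds named here, no measured step touches this change, and the three values at the limit give no direction to lean on. Compound 4 is therefore expected to behave like its three relatives, with an estimated value of 50000 nM, lying somewhere between 10000 nM and 200000 nM, and most likely reported again only as a limit. The expected step of a number no higher from compound 3 to compound 4 (the limit leaves the size open) amounts to none beyond the scatter.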

Compound 4, half-maximal inhibitory concentration: 32200 nM
Estimate against measurement, compound 4: 1.6-fold (0.19 log units) above; the measured number falls inside the stated range.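

In this assay, compound 4 is the only one of the four shown that gives a measured number and not a limit, so a compound with the larger 4-methoxybenzyl at this aromatic carbon can be placed on the scale. Putting 4-methoxybenzyl in place of acetyl gives an at least 1.5-fold lower number from compound 3 to compound 4 (0.19 log units; that floor lies within the scatter), and putting it in place of fluoro gives an at least 1.5-fold lower number from compound 1 to compound 4 (0.19 log units; that floor lies within the scatter). Both steps are known only as floors, not as full sizes, and neither floor shows a change beyond the scatter, because one end of each step is a limit: the limit of > 50000 nM in this assay, at which 3 of the 4 values shown sit.

The steps among compound 1, compound 2 and compound 3 still cannot be read, so the comparison of acetyl with fluoro and of the two drawn forms of the double bond remains without a size. As far as these compounds go, it also stays open whether the gain in readability belongs to the added aromatic ring or to its methoxy group, and whether a plain benzyl, an amine or a carboxylic acid at this same aromatic carbon would give a lower number in this assay.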